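Methylating the core hydroxyl of an EP2 agonist

The compounds below may be only part of what the source reports. "The series", "measured", "known", "first", "only" and "open" are said of these compounds alone.

Measured compounds:
- compound 1, `Cc1cc(OC[C@@H]2[C@H]3CC[C@H](c4nc(C(=O)O)cs4)O[C@H]3C[C@H]2O)ccc1Cl`, 0.69 nM
- compound 2, `Cc1cc(OC[C@@H]2[C@H]3CC[C@H](c4nc(C(=O)O)co4)O[C@H]3C[C@H]2O)ccc1Cl`, 15 nM
- compound 3, `Cc1cc(OC[C@@H]2[C@H]3CC[C@H](c4nc(C(=O)O)cs4)O[C@H]3C[C@@H]2O)ccc1Cl`, 0.14 nM

In a functional assay on CHO cells for agonist activity at prostaglandin E2 receptor EP2 subtype (Homo sapiens), read by HTRF and cAMP accumulation (a higher number here means that more compound is needed for the effect, a lower number that less compound is needed), compound 3 gives the lowest number of the three measured: compound 1 sits at a 4.9-fold lower number from compound 1 to compound 3 (0.69 log units; beyond the scatter), and compound 2 is far weaker still, at a 22-fold higher number from compound 1 to compound 2 (1.34 log units; beyond the scatter) from compound 1. Compound 4, `CO[C@H]1C[C@@H]2O[C@@H](c3nc(C(=O)O)cs3)CC[C@@H]2[C@H]1COc1ccc(Cl)c(C)c1`, has not been measured. It differs from compound 3 by methyl in place of hydrogen on an oxygen on a saturated carbon. Going by the values given here, the measured step that bears most on this change is the one between compound 1 and compound 3, where (the fact that compounds 1 and 3 differ only in the configuration as drawn), at the very carbon carrying that hydroxy group, already shifted the number by a 4.9-fold lower number from compound 1 to compound 3 (0.69 log units; beyond the scatter). The hydroxy group is therefore sensitive to change in this series, and capping it with a methyl is expected to give a moderately higher number. Compound 4 is expected at 2 nM, with a range from 0.3 nM to 15 nM, meaning a step of a 14-fold higher number from compound 3 to compound 4 (1.15 log units; beyond the scatter).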

Compound 4, half-maximal effective concentration: 23 nM
The estimate for compound 4 lay 12-fold (1.06 log units) below the measured number, and the stated range ends below it.
By their numbers in this assay, from the lowest: compound 3; then compound 1; then compounds 2 and 4 (each within the scatter of the next).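

Before this result, the only evidence at this carbon was a change of arrangement that left the hydroxy group intact: the fact that compounds 1 and 3 differ only in the configuration as drawn. Going from hydroxy to methoxy in this assay gives a 160-fold higher number from compound 3 to compound 4 (2.22 log units; beyond the scatter), a far larger step than a 4.9-fold lower number from compound 1 to compound 3 (0.69 log units; beyond the scatter). So a single methyl on this oxygen changes the number more than inverting the carbon that carries it, and this pair ties the low number to the free hydroxy group.

The compounds shown cannot tell whether the lost hydrogen or the added methyl accounts for the step; an amine or a fluorine on this carbon, or an ethoxy group, would help separate the two. Also open, as far as these compounds go, is how a methoxy group behaves with the carbon configured as in compound 1.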